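This account rests on a few compounds, and the source may have more. Where it says the series, first, only, none or still open, it means among the compounds named here.

Of the compounds shown here, three built on one shared core have been measured in a functional assay on PC-3 cells (Homo sapiens) for cytotoxicity, read by MTT assay, with a stated time of 72 h; a lower number here means a stronger inhibitor, a higher number a weaker inhibitor. Compound 1 `FC(F)(F)c1ccc(CSc2nc(Nc3ccccc3)c3ccccc3n2)cc1` gives 20000 nM. Compound 2 `CCOc1ccccc1Nc1nc(SCc2ccc(C(F)(F)F)cc2)nc2ccccc12` gives 26200 nM, and compound 3 `CCOc1ccc(Nc2nc(SCc3ccc(C(F)(F)F)cc3)nc3ccccc23)cc1` gives 32100 nM. Compound 3 sits at the upper end of these three numbers, yet it is not separated from the others: a 1.6-fold higher number from compound 1 to compound 3 (0.21 log units; within the scatter) and a 1.2-fold higher number from compound 2 to compound 3 (0.09 log units; within the scatter), so all three read as one level here.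

The step in question leads to compound 4 `Fc1ccc(Nc2nc(SCc3ccc(C(F)(F)F)cc3)nc3ccccc23)cc1Cl`, which carries 3-chloro-4-fluorophenyl in place of 4-ethoxyphenyl on a nitrogen on an aromatic ring. Going by the values given here, two measured steps bear on it. Both also change the group on that nitrogen. Moving the ethoxy from one place on the phenyl to another gave a 1.2-fold higher number from compound 2 to compound 3 (0.09 log units; within the scatter), and adding the ethoxy at all gave a 1.3-fold higher number from compound 1 to compound 2 (0.12 log units; within the scatter). Among the compounds with values here, neither involved a chlorine or a fluorine, so no measured step tests this exact exchange; what the numbers do show is that changes to the phenyl on that nitrogen have so far left this assay unmoved. A step of no size beyond the scatter is therefore expected, and compound 4 is estimated at 25000 nM, within a range from 8000 nM to 80000 nM. The step this estimate implies is a 1.3-fold lower number from compound 3 to compound 4 (0.11 log units; within the scatter).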

Compound 4, half-maximal inhibitory concentration: 18600 nM
The estimate for compound 4 lay 1.3-fold (0.13 log units) above the measured number, within the range that was stated.
By their numbers in this assay, from the lowest: compounds 4, 1, 2 and 3 (each within the scatter of the next).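

Going by these compounds alone, putting 3-chloro-4-fluorophenyl on a nitrogen on an aromatic ring brings halogens to this position for the first time, and in this assay the result is a 1.7-fold lower number from compound 3 to compound 4 (0.24 log units; within the scatter), a 1.4-fold lower number from compound 2 to compound 4 (0.15 log units; within the scatter) and a 1.1-fold lower number from compound 1 to compound 4 (0.03 log units; within the scatter). The earlier compounds shown here tested only an added ethoxy and its shift around the phenyl, whereas this change swaps the whole 4-ethoxyphenyl for a group with two different atoms on the ring and, by count, no hydrogen-bond acceptor, and the number still stays level with the other three. All four compounds therefore read as one level in this assay, so this wider change at the position is also without a visible effect, and no supporting measurement is available to say anything further about this result.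

Every group shown on that nitrogen is still a six-membered aromatic ring of carbon only, so it remains open whether a pyridine ring, a saturated ring such as morpholine, or a phenyl carrying a carboxylic acid or an amine would give a step beyond the scatter. The rest of the structure is the same in all four compounds, so these numbers also say nothing about changes made anywhere else on it.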